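Trimming the amine on a chlorotriazine herbicide scaffold

A few compounds are considered here, and "the series" means these few. Any claim that something is new, unique, unknown or untested is made for them only; others in the source may bear on it.

Compound 1 `CC(C)Nc1nc(Cl)nc(N[C@@H](C)c2ccccc2)n1` gives 23400 nM; compound 2 `CC(C)N(c1nc(Cl)nc(N[C@H](C)c2ccccc2)n1)C(C)C` gives 1620 nM; compound 3 `CCN(c1nc(Cl)nc(N[C@H](C)c2ccccc2)n1)C(C)C` gives 3550 nM.

Of the compounds shown here, three have been measured in an ADME assay on the whole organism for inhibition, with Oryza sativa as the target, with a stated time of 4 days; a higher number here means a weaker inhibitor, a lower number a stronger inhibitor. Compound 3 stands second highest of the three numbers: compound 2 sits below it, with the step of a 2.2-fold higher number from compound 2 to compound 3 (0.34 log units; beyond the scatter), while compound 1 sits well above it, at the weakest end of the set.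

Compound 4 `CC(C)Nc1nc(Cl)nc(N[C@H](C)c2ccccc2)n1` is the next compound to be measured. It differs from compound 3 by hydrogen in place of ethyl on a nitrogen on an aromatic ring, so the ethyl(isopropyl)amino group of compound 3 becomes an isopropylamino group in compound 4.

Going by the values given here, the only measured step that bears on this is the one from compound 2 to compound 3, where taking a methyl off the chain next to that nitrogen already gave a modest rise in the number. Among the compounds with values here, compound 4 goes further in the same direction, removing a whole ethyl from the nitrogen itself, and compound 1, the only compound in the set with a single substituent on that nitrogen, gives the highest number of all. Compound 4 is therefore expected to weaken further, with the step of a 2.5-fold higher number from compound 3 to compound 4 (0.40 log units; beyond the scatter). Compound 4 is estimated to give 9000 nM, within a range from 3500 nM to 25000 nM.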

Compound 4, half-maximal inhibitory concentration: 5370 nM
For compound 4 the middle estimate is 1.7-fold (0.22 log units) above the measured one, and the stated range covers the measured number.
By their numbers in this assay, from the lowest: compound 2; then compounds 3 and 4 (each within the scatter of the next); then compound 1.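

In this assay, hydrogen in place of ethyl on this nitrogen gives a 1.5-fold higher number from compound 3 to compound 4 (0.18 log units; within the scatter), so that step cannot be told apart from repeat measurements, whereas hydrogen in place of isopropyl gives a 3.3-fold higher number from compound 2 to compound 4 (0.52 log units; beyond the scatter), which can. Compound 1 had looked as if it might show the effect of leaving a single substituent on this nitrogen, but compound 4 carries the same isopropylamino group, and the step is a 4.4-fold lower number from compound 1 to compound 4 (0.64 log units; beyond the scatter). The high number of compound 1 therefore goes with its stereocentre at a saturated chain carbon, drawn S there and R in compound 4, and not with the amine, because the comparison rests on this: the fact that compounds 1 and 4 differ only in the configuration as drawn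

This is the only such mirror-image pair among the compounds shown, so it remains open whether the S drawing would give a similar gap alongside the ethyl(isopropyl)amino group of compound 3 or the larger amine of compound 2. Going by these compounds, it also remains open how a smaller group on this nitrogen, such as methyl, or a ring such as cyclopropyl, would compare with isopropyl.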